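This account rests on a few compounds, and the source may have more. Where it says the series, first, only, none or still open, it means among the compounds named here.

Measured compounds:
- compound 2, `C=CCn1c(=O)/c(=C\c2cccc(Cl)c2Cl)[nH]c(=O)/c1=C\c1ccccc1OC`, in a functional assay on MOLT-4 cells (Homo sapiens) for cytotoxicity, read by CCK-8 assay, with a stated time of 72 h (a higher number here means a weaker inhibitor, a lower number a stronger inhibitor), gives 1200 nM
- compound 1, `COc1ccccc1/C=c1/[nH]c(=O)/c(=C\c2cccc(Cl)c2Cl)[nH]c1=O`, in this assay gives "not determined" (no result reported)
- compound 3, `COc1ccccc1/C=c1\c(=O)[nH]/c(=C/c2cccc(Cl)c2Cl)c(=O)n1C`, in this assay gives "not determined" (no result reported)

For the measured compounds named here, compound 2 holds the only number in this assay; compound 1 and compound 3 share the same core but carry no reported result, so nothing can be said about how the three compare. Going by the values given here, there is therefore no measured step within this set to lean on, and no pair of compounds whose difference has been turned into a number.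

Compound 4, `C=CCn1c(=O)/c(=C\c2ccc(C)cc2)[nH]c(=O)/c1=C\c1ccccc1OC`, is the next compound to be tested. It keeps the core and the allyl substituent of compound 2 and differs in one place: 4-methylphenyl in place of 2,3-dichlorophenyl on a double-bonded chain carbon bound to an aromatic carbon. Among the compounds with values here, since no step between measured compounds is available, the size and direction of this change cannot be read from the data; the expectation below rests on compound 2 alone, with wide uncertainty. A change of a ring substituent of this kind is expected to shift potency only modestly, most likely within or just beyond the usual scatter, and if anything toward a weaker inhibitor. Compound 4 is expected to give an estimated 2500 nM in this assay, within a range of 800 nM to 8000 nM. The step this implies, a 2.1-fold higher number from compound 2 to compound 4 (0.32 log units; beyond the scatter), is an estimate rather than a measured result.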

Compound 4, half-maximal inhibitory concentration: "not active" (no number reported)
No number was reported for compound 4, and the estimate cannot be compared.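

In this assay, for the compounds shown here, compound 4 gives "not active" (no number reported) and so no step from compound 2 can be read as a number. No measured evidence shown here bears on this result. The compounds shown leave open how much potency differs between the 2,3-dichlorophenyl and 4-methylphenyl groups, and how compound 1 and compound 3 compare with compound 2.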